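The source may hold more compounds than are shown below. What is called first, only, known or untested is meant among the compounds shown, and "the series" means these compounds.

Measured so far:
compound 1 `CCN(Cc1ccccn1)c1cccc(C(=O)N2CCc3ccc(OS(N)(=O)=O)cc3C2)c1`: 19.9%
compound 2 `CCN(Cc1ccc(F)cc1)c1ccc(C(=O)N2CCc3ccc(OS(N)(=O)=O)cc3C2)cc1`: 91.2%

In an assay on HEK293 cells for inhibition of Steryl-sulfatase (Homo sapiens), tested at 1 uM (a lower number here means a weaker effect, a higher number a stronger effect of the compound at the concentration tested), compound 1 gives 19.9%, the lower of the two numbers. In this assay compound 2 gives 91.2%, a gap that lies beyond the scatter of the method. Among the measured compounds shown here, compound 2 differs from compound 1 in more than one place, so no single-point step between them can be read off.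

Compound 3 `CCN(Cc1ccccc1)c1cccc(C(=O)N2CCc3ccc(OS(N)(=O)=O)cc3C2)c1` is the untested member. Relative to compound 1 it carries phenyl in place of pyridin-2-yl on a saturated chain carbon bound to a nitrogen on an aromatic ring. The rest of the shared core is unchanged. For the measured compounds named here, no measured pair shows this change on its own, so the expected step in this assay from compound 1 to compound 3 is estimated to be upward but modest, a number 20.1 percentage points higher from compound 1 to compound 3 (beyond the scatter), with considerable uncertainty. Compound 3 is therefore expected to give about 40% in this assay, in a range from 15% to 75%.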

Compound 3, a percentage reported as inhibition, at one concentration (the size of the read-out at that concentration, not a potency): 69%
The estimate for compound 3 lay 29 percentage points below the measured number; the measured number falls inside the stated range.
By their numbers in this assay, from the lowest: compound 1; then compound 3; then compound 2.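

In this assay, phenyl in place of pyridin-2-yl on a saturated chain carbon bound to a nitrogen on an aromatic ring gives a large change, a number 49.1 percentage points higher from compound 1 to compound 3 (beyond the scatter), with the rest of the shared core unchanged. Among the compounds shown here, this is the only comparison here that isolates one place, and it shows that the read-out at this position depends on which six-membered aromatic ring is present, although both rings count the same number of heavy atoms. Nothing available bears on why the change is this large.

The compounds shown leave open how other groups at this position, such as cyclohexyl or pyridin-4-yl, would compare with phenyl. They also leave open whether the same change would give a similar step on another core, and compound 2 cannot answer this, as it differs from compound 3 in more than one place.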